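Methyl for hydrogen on the hydroxyethyl chain

The compounds below may be only part of what the source reports. "The series", "measured", "known", "first", "only" and "open" are said of these compounds alone.

Compound 1, `Cc1cc(C(=O)O)ccc1CN1CCC[C@H](O[C@H](CO)c2ccccc2)[C@@H]1c1ccccc1`, gives in an assay on isolated protein for activation of cGMP-dependent protein kinase 1 (Homo sapiens), read by ADP-Glo, with stated times of 30 min and 2 h (on this read-out higher numbers stand for an effect only at larger amounts of compound and lower numbers for an effect already at smaller amounts), a value that is a limit of the assay, > 200000 nM.
Compound 2, `Cc1cc(C(=O)O)ccc1CN1CCC[C@H](O[C@H](CO)c2cc(F)cc(F)c2)[C@@H]1c1ccccc1`, gives in this assay a limit of the assay, > 200000 nM.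
Compound 3, `Cc1cc(C(=O)O)ccc1CN1CCC[C@H](OC(c2cc(Cl)cc(Cl)c2)C(C)O)[C@@H]1c1ccccc1`, gives in this assay a limit of the assay, > 196000 nM.

Compound 3 thus stands where the other two measured compounds stand: at a limit rather than at a number. Two of the three values sit at the limit of > 200000 nM in this assay, at which 2 of the 3 values shown sit, and one sits at the limit of > 196000 nM in this assay, at which 1 of the 3 values shown sits. Compound 4, `Cc1cc(C(=O)O)ccc1CN1CCC[C@H](OC(c2cc(Cl)cc(Cl)c2)C(C)(C)O)[C@@H]1c1ccccc1`, differs from compound 3 by methyl in place of hydrogen on a saturated chain carbon bound to an oxygen on a saturated carbon and two saturated chain carbons; cut one bond further out, the change reads 1-hydroxyethyl to 1-hydroxy-1-methylethyl. The measured steps that could bear on this change are a step that the two limits leave unreadable from compound 1 to compound 2, a step that the two limits leave unreadable from compound 1 to compound 3 and a step that the two limits leave unreadable from compound 2 to compound 3. None of them has a readable size; the limits leave them open. The data therefore give no ground for a step in either direction in this assay, and no change beyond the scatter is expected. Compound 4 is accordingly expected to remain at a limit of the assay, an estimated step that the limit leaves unreadable from compound 3 to compound 4. For compound 4 the estimate is 200000 nM, with an expected range from 80000 nM to 2000000 nM.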

Compound 4, half-maximal effective concentration: 121000 nM
Compound 4: middle estimate off by 1.7-fold (0.22 log units), on the high side, and the stated range covers the measured number.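

With the 1-hydroxy-1-methylethyl group, compound 4 is the first of the four compounds shown to give a number rather than a limit of the assay in this assay, and the other steps among them cannot be read. Methyl in place of hydrogen on this saturated chain carbon gives an at least 1.6-fold lower number from compound 3 to compound 4 (0.20 log units; that floor lies within the scatter), so this place accepts the added methyl with no sign of a loss, though the floor of the step does not go beyond the scatter. The true size of the step stays unknown, since compound 3 holds a limit of the assay and not a number: the limit of > 196000 nM in this assay, at which 1 of the 4 values shown sits.

On these data alone, whether the same methyl would also bring a number with the phenyl of compound 1 or the 3,5-difluorophenyl of compound 2 remains open, and so does how far compound 4 really lies from compound 3. Also open, as far as these compounds go, is what a longer chain such as ethyl on this carbon, or an amine in place of the hydroxy group, would do in this assay.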